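The compounds below may be only part of what the source reports. "The series", "measured", "known", "first", "only" and "open" are said of these compounds alone.

Compound 1 `NC(=O)c1c(NC(=O)c2ccccc2Cl)sc2c1CCN(C(=S)Nc1ccccc1I)C2` and compound 2 `NC(=O)c1c(NC(=O)c2ccccc2Cl)sc2c1CCN(C(=S)Nc1ccccc1C(F)(F)F)C2` share one core. In a functional assay on MKN-74 cells (Homo sapiens) for antiproliferative activity, with a stated time of 24 h (a higher number here means a weaker inhibitor, a lower number a stronger inhibitor), compound 1 gives 2630 nM and compound 2 gives 1870 nM. The change between them is trifluoromethyl in place of iodo on an aromatic carbon, and it made the step of a 1.4-fold lower number from compound 1 to compound 2 (0.15 log units; within the scatter). Compound 3 `NC(=O)c1c(NC(=O)c2ccccc2I)sc2c1CCN(C(=S)Nc1ccccc1Cl)C2` is built from the same atoms as compound 1, joined differently; the difference between the two cores is not broken down here. In this assay compound 3 gives 17500 nM, the highest of the three numbers. Among the compounds with values here, compound 4 `NC(=O)c1c(NC(=O)c2ccccc2C(F)(F)F)sc2c1CCN(C(=S)Nc1ccccc1Cl)C2` differs from compound 3 by trifluoromethyl in place of iodo on an aromatic carbon, the same change as the one from compound 1 to compound 2, at a place described in the same words. Because the step of a 1.4-fold lower number from compound 1 to compound 2 (0.15 log units; within the scatter) lay within the scatter, the change is expected to repeat as a 1.3-fold lower number from compound 3 to compound 4 (0.13 log units; within the scatter). Compound 4 is therefore estimated at 13000 nM in this assay, between 6000 nM and 30000 nM.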

Compound 4, half-maximal inhibitory concentration: 21900 nM
Compound 4: the middle estimate sits 1.7-fold (0.23 log units) below what was measured; low and high end bracket the measured number.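

In this assay, replacing iodo with trifluoromethyl on the second core gives a 1.3-fold higher number from compound 3 to compound 4 (0.10 log units; within the scatter). Set beside the same change on the first core, the two steps do not differ measurably: the same change on two cores in this assay, a 1.4-fold lower number (0.15 log units; within the scatter) from compound 1 to compound 2 and a 1.3-fold higher number (0.10 log units; within the scatter) from compound 3 to compound 4, 1.8-fold (0.25 log units) apart, within the scatter of two such steps. This shows that in these two pairs the change left the number within ordinary measurement noise on either core, but two pairs cannot show that the same holds on other cores in the series, and steps this small cannot reveal a real but slight difference between cores.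

The compounds shown leave open what an amine or a carboxylic acid would do on this aromatic carbon. They also leave open whether such a group would carry from one core to the other.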